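Changing the Halogen on the Benzyl Group

The source may hold more compounds than are shown below. What is called first, only, known or untested is meant among the compounds shown, and "the series" means these compounds.

Of the compounds shown here, three sharing one core have been tested in a functional assay on the whole organism (artery, strain albino) with Rattus norvegicus as the target, with a stated time of 600 min, at a dose of 10 mg/kg by the oral route; on this read-out lower numbers stand for less inhibition and higher numbers for more inhibition at the one dose given (going by the name of the read-out). Compound 1 `COc1ccc(C2N=C(SCc3ccccc3Cl)NC(C)=C2C(=O)Nc2ccc(F)cc2)cc1OC` gives 30.3%. Compound 2 `CC1=C(C(=O)Nc2ccc(Br)cc2)C(c2ccc(Cl)cc2Cl)N=C(SCc2ccccc2Cl)N1` gives 24.6%. Compound 3 `COc1ccc(C2N=C(SCc3ccccc3Cl)NC(C)=C2C(=O)Nc2ccc(Br)cc2)cc1` gives 13.3%, the lowest of the three: compound 2 and compound 1 stand above it by gaps that go beyond the scatter. Among the compounds with values here, the only step between two compounds that differ in a single place, a number 11.3 percentage points lower from compound 2 to compound 3 (beyond the scatter), concerns the group on the saturated ring carbon and nothing else.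

Compound 4 `COc1ccc(C2N=C(SCc3ccc(F)cc3)NC(C)=C2C(=O)Nc2ccc(Br)cc2)cc1` has not yet been measured. It differs from compound 3 in 4-fluorophenyl in place of 2-chlorophenyl on a saturated chain carbon bound to a sulfur. Within the data shown here, this change sits on the saturated chain carbon bound to a sulfur, a part of the molecule that no measured step has touched, so none of the steps seen so far bears on it directly. With nothing at this position to lean on, the expectation is a change no larger than the scatter, in either direction. The step of a number 0.7 percentage points higher from compound 3 to compound 4 (within the scatter) is therefore expected to be small. Compound 4 is estimated at 14%, within a range from 2% to 32%.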

Compound 4, a percentage reported as inhibition, in the whole organism at one dose (the size of the read-out at that dose, not a potency): 24.1%
Compound 4: middle estimate off by 10.1 percentage points, on the low side; low and high end bracket the measured number.
By their numbers in this assay, from the lowest: compound 3; then compounds 4, 2 and 1 (each within the scatter of the next).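

In this assay, the group on the saturated chain carbon bound to a sulfur proves able to move the read-out: putting 4-fluorophenyl in place of 2-chlorophenyl gives a number 10.8 percentage points higher from compound 3 to compound 4 (beyond the scatter). Within the data shown here, this is the first look at this position, and it rests on a single pair in which the rest of the molecule stays the same, so it shows that this position matters in this one setting and no more. Nothing available explains why the number rises here.

The swap changes two things at once, the kind of halogen and where it sits on the phenyl ring, as the names 2-chlorophenyl and 4-fluorophenyl show, so the pair cannot say which of the two accounts for the step, or whether both contribute. As far as these compounds go, it also remains open how a plain phenyl ring with no halogen, a methoxy-bearing phenyl ring or a longer chain such as phenylethyl would read at this position, and whether the same step would appear with a different group on the saturated ring carbon.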